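A few compounds are considered here, and "the series" means these few. Any claim that something is new, unique, unknown or untested is made for them only; others in the source may bear on it.

Of the compounds shown here, two share one core and have been measured in an assay on L1.2 cells for binding affinity to C-C chemokine receptor type 8 (Homo sapiens); on this read-out lower numbers stand for stronger inhibition and higher numbers for weaker inhibition. Compound 1, `CCOC(=O)N1CCC(NS(=O)(=O)c2ccc(NC(=O)c3ccccc3)c3ccccc23)CC1`, gives 0.17 nM in this assay. Compound 2, `Cc1ccccc1C(=O)Nc1ccc(S(=O)(=O)NC2CCN(C(=O)CO)CC2)c2ccccc12`, gives 5.4 nM in this assay. Of the two numbers, compound 2 has the higher one, and its gap to compound 1 lies beyond the usual scatter of repeated measurements; the two differ in more than one place, so this gap cannot be traced to a single change.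

Compound 3, `Cc1ccccc1C(=O)Nc1ccc(S(=O)(=O)NC2CCN(C(=O)N3CCOCC3)CC2)c2ccccc12`, has not yet been measured. It is derived from compound 2 by one change: morpholin-4-yl in place of hydroxymethyl on a carbonyl carbon. The other parts of the molecule stay as in compound 2.

For the measured compounds named here, no single-point step between measured compounds is available to gauge this change, so the expectation rests on compound 2 alone. The step from compound 2 to compound 3 is expected to be small, leaning toward a lower number, and might not exceed the scatter; the estimated step is a 1.8-fold lower number from compound 2 to compound 3 (0.26 log units; within the scatter). For compound 3 in this assay the estimate is 3 nM, with a range from 0.8 nM to 12 nM.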

Compound 3, inhibition constant: 6.3 nM
The estimate for compound 3 lay 2.1-fold (0.32 log units) below the measured number; the measured number falls inside the stated range.
By their numbers in this assay, from the lowest: compound 1; then compounds 2 and 3 (each within the scatter of the next).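

In this assay, morpholin-4-yl in place of hydroxymethyl on the carbonyl carbon gives a 1.2-fold higher number from compound 2 to compound 3 (0.07 log units; within the scatter), so the two numbers cannot be told apart. This position therefore accepts a group of 6 heavy atoms with a six-membered non-aromatic ring in place of one of 2 heavy atoms with no ring, and the read-out does not separate the two compounds. The same holds although hydroxymethyl carries 1 hydrogen-bond donor and morpholin-4-yl carries 0, but nothing available explains why the two numbers match.

Going by these compounds, this is a single pair with the rest of the molecule held constant, so it remains open whether a different group on the same carbonyl carbon, such as dimethylamino, piperazin-1-yl or a longer chain like 2-hydroxyethyl, would also leave the number unchanged. On these data alone, it also remains open what sets compound 1 apart, since it differs from both compound 2 and compound 3 in more than one place and those steps cannot be read.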